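This account rests on a few compounds, and the source may have more. Where it says the series, first, only, none or still open, it means among the compounds named here.

Compound 1 `CCc1oc([C@H](C)/C=C(\C)[C@H](OC(C)=O)[C@H](C)[C@@H](OC(=O)CC(C)C)[C@@H](C)c2oc([C@@H](C)[C@@H](O)CC)c(C)c(=O)c2C)c(C)c(=O)c1C` stands as the stronger of the two measured compounds in this set. In a functional assay on MCF7 cells (Homo sapiens) for inhibition, read by MTT assay, with a stated time of 72 h (a lower number here means a stronger inhibitor, a higher number a weaker inhibitor), compound 1 gives 15000 nM. Within the data shown here, compound 2 `CCC(=O)[C@@H](C)c1oc([C@H](C)[C@@H]2O[C@](O)([C@@H](C)c3oc(CC)c(C)c(=O)c3C)[C@@H](C)[C@@H](O)[C@@H]2C)c(C)c(=O)c1C` is the only other measured member, and in this assay compound 2 gives 87000 nM, a number that lies beyond the usual scatter from compound 1, so compound 1 holds the lowest value of the two. Compound 3 `CCC(=O)O[C@@H](/C(C)=C/[C@@H](C)c1oc(CC)c(C)c(=O)c1C)[C@H](C)[C@@H](OC(=O)CC(C)C)[C@@H](C)c1oc([C@@H](C)[C@@H](O)CC)c(C)c(=O)c1C` has not yet been tested. It differs from compound 1 by methyl in place of hydrogen on a saturated chain carbon bound to a carbonyl carbon, which amounts to the change from acetyl to propanoyl at that position. Among the measured compounds shown here, no measured pair in this set shares this change, so there is no recorded step to read it from. A single added carbon on a saturated chain carbon bound to a carbonyl carbon is a small alteration of a large molecule, and the step from compound 1 to compound 3 is expected to be small, in no clear direction, and likely within the scatter of repeated measurements, so compound 3 is expected to show no change at the digits printed from compound 1 to compound 3 (within the scatter). The estimate for compound 3 in this assay is 15000 nM, with a likely range from 6000 nM to 40000 nM.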

Compound 3, half-maximal inhibitory concentration: 12000 nM
The estimate for compound 3 lay 1.3-fold (0.10 log units) above the measured number; the measured number falls inside the stated range.
By their numbers in this assay, from the lowest: compounds 3 and 1 (each within the scatter of the next); then compound 2.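

In this assay, among these compounds, the change from acetyl to propanoyl gives a 1.3-fold lower number from compound 1 to compound 3 (0.10 log units; within the scatter), the first recorded step at this position, and it lies within the scatter. Among the compounds shown here, until now the position had no step of its own, since compound 2 differs from compound 1 in more than one place and could not speak to it; the new pair shows that methyl in place of hydrogen on a saturated chain carbon bound to a carbonyl carbon leaves the reading indistinguishable from that of compound 1. This one step therefore shows that the acetoxy group can become propanoyloxy without a readable shift in this assay, and no supporting measurement is available to explain that result. As far as these compounds go, what remains open is how far this holds: a longer chain such as butanoyl or hexanoyl, or an amine or a carboxylic acid carried at the end of the chain, could behave quite differently from the single added carbon seen here. From the compounds shown here alone, it is also open whether the same change would read alike on the 3-methylbutanoyl ester elsewhere on the shared core.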